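Notes on the step from compound 2 to compound 3

This account rests on a few compounds, and the source may have more. Where it says the series, first, only, none or still open, it means among the compounds named here.

Two compounds of the series carry numbers. Compound 1 `CCCCCc1cc(Nc2ccc(OC)cc2)cc(=O)o1` in a functional assay on DU-145 cells (Homo sapiens) for cytotoxicity, read by MTT assay, with a stated time of 72 h (a lower number here means that less compound is needed, a higher number that more compound is needed for the effect), gives 5.94 uM. Compound 2 `COc1ccc(Nc2cc(-c3ccco3)oc(=O)c2)cc1` in this assay gives 1.95 uM. Among the measured compounds shown here, the single measured step, a 3.0-fold lower number from compound 1 to compound 2 (0.48 log units; beyond the scatter), concerns the same aromatic carbon that is changed again here. Compound 2 therefore stands with the lowest of the two numbers, and its nearest neighbour is compound 1, whose number lies higher by that step.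

Compound 3 `COc1ccc(Nc2cc(C(C)C)oc(=O)c2)cc1` has not been measured. It differs from compound 2 by isopropyl in place of furan-2-yl on an aromatic carbon. For the measured compounds named here, the only step that bears on this place is a 3.0-fold lower number from compound 1 to compound 2 (0.48 log units; beyond the scatter), which exchanged an alkyl chain for furan-2-yl and gave a modest gain. The present change removes the furan-2-yl again and installs isopropyl, so a partial return toward the number of compound 1 is expected, a modest rise rather than a step within the scatter. For compound 3 in this assay the expected number is 4 uM, with a range from 1.5 uM to 11 uM. This corresponds to an expected step of a 2.1-fold higher number from compound 2 to compound 3 (0.31 log units; beyond the scatter).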

Compound 3, concentration for half-maximal effect: > 30 uM
Compound 3: only a limit was reported; the forecaster's own chance of this, stated with the estimate: 5%; at least 7.5-fold (0.87 log units) between middle value and limit.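

Compound 3's reading in this assay is a limit of the assay and not a number: the limit of > 30 uM in this assay, at which 1 of the 3 values shown sits. Among the compounds shown here, at this aromatic carbon next to the ring oxygen, the change to isopropyl gives an at least 15-fold higher number from compound 2 to compound 3 (1.18 log units; beyond the scatter), a large step where the only earlier change at this place was modest, so the position tolerates replacement of furan-2-yl far less well than that earlier step indicated. The two alkyl groups also do not behave alike, as the change from pentyl to isopropyl gives an at least 5.0-fold higher number from compound 1 to compound 3 (0.70 log units; beyond the scatter), so alkyl groups at this carbon cannot be treated as one class, and furan-2-yl gives the lowest number of the three groups shown.

The compounds shown do not separate the features that change together here, since furan-2-yl differs from isopropyl at once in heavy atoms, in the ring and in the hydrogen-bond acceptor, while pentyl and isopropyl differ in both chain length and shape. From the compounds shown here alone, a thiophene-2-yl or phenyl group at this carbon would test the role of the aromatic ring, a longer chain such as heptyl would extend the alkyl comparison, and the true position of compound 3 beyond its limit remains open.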